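Swapping Methoxy for Trifluoromethyl on a Urea Series

The source may report more compounds than this note shows. Statements on the series, on what has been measured and on what is new or still open speak of the compounds shown alone.

Compound 1, `COc1cc(Br)ccc1Nc1cc(NC(=O)Nc2c(Cl)cccc2Cl)ncn1`: 43%
Compound 2, `COc1cc(Nc2cc(NC(=O)Nc3c(Cl)cccc3Cl)ncn2)cc(OC)c1`: 60%

In a functional assay on NCI-H226 cells (Homo sapiens) for inhibition, read by MTT assay, with a stated time of 48 h, tested at 10 uM (on this read-out higher numbers stand for more inhibition at the one concentration tested (going by the name of the read-out) and lower numbers for less inhibition), compound 2 gives 60%, the highest of the two numbers; compound 1 gives 43%, a gap beyond the usual scatter. Compound 3, `COc1cc(Nc2cc(NC(=O)Nc3c(Cl)cccc3Cl)ncn2)cc(C(F)(F)F)c1`, has not yet been measured. It differs from compound 2 in one place: trifluoromethyl in place of methoxy on an aromatic carbon. For the measured compounds named here, no measured pair shows this change, so its effect in this assay is unknown. A modest step in either direction, possibly not beyond the scatter, is expected. Compound 3 is therefore expected to give 50%, within 25% to 75%, a change of a number 10 percentage points lower from compound 2 to compound 3 (within the scatter).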

Compound 3, a percentage reported as inhibition, at one concentration (the size of the read-out at that concentration, not a potency): 33.1%
Estimate against measurement, compound 3: 16.9 percentage points above, within the range that was stated.
By their numbers in this assay, from the lowest: compounds 3 and 1 (each within the scatter of the next); then compound 2.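

Trifluoromethyl in place of methoxy on this aromatic carbon gives a clear step in inhibition (a number 26.9 percentage points lower from compound 2 to compound 3 (beyond the scatter)), so the group at this position matters to the read-out. The earlier compounds shown here could not show this, as they formed no pair differing in one place. Nothing at hand explains the drop.

On these data alone, whether a methyl group, an amine or a carboxylic acid at this position would keep inhibition closer to that of compound 2 remains open. So does whether the same swap would have a similar effect with the remaining methoxy group absent.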